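The source may report more compounds than this note shows. Statements on the series, on what has been measured and on what is new or still open speak of the compounds shown alone.

Three quinolone carboxylic acids have been tested in a functional assay on V79 cells (Cricetulus griseus) for cytotoxicity, read by colony formation; on this read-out higher numbers stand for weaker inhibition and lower numbers for stronger inhibition. Compound 1 `O=C(O)c1cn(C2CC2)c2c(Cl)c(N3CCCC3)c(F)cc2c1=O` is the reference: in this assay compound 1 gives 150 ug/mL. Compound 2 `O=C(O)c1cn(C2CC2)c2c(C(F)(F)F)c(N3CCCC3)c(F)cc2c1=O` differs from it by trifluoromethyl in place of chloro on an aromatic carbon, and compound 2 gives 280 ug/mL, which is a 1.9-fold higher number from compound 1 to compound 2 (0.27 log units; within the scatter). Compound 3 `CC1CN(c2c(F)cc3c(=O)c(C(=O)O)cn(C4CC4)c3c2Cl)CCN1` carries a different amine on the core, (3-methylpiperazin-1-yl in place of pyrrolidin-1-yl on an aromatic carbon), and compound 3 gives 45 ug/mL, a change of a 3.3-fold lower number from compound 1 to compound 3 (0.52 log units; beyond the scatter). Among the three, compound 3 stands at the lowest number, and both of its gaps, to compound 1 and to compound 2, are beyond the scatter, so compound 3 is the strongest inhibitor in this set.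

Compound 4 `CC1CN(c2c(F)cc3c(=O)c(C(=O)O)cn(C4CC4)c3c2C(F)(F)F)CCN1` has not yet been measured. It is related to compound 3 as compound 2 is to compound 1: trifluoromethyl in place of chloro on an aromatic carbon. Among the compounds with values here, this is the same kind of change as the one from compound 1 to compound 2, not the same change, since the surroundings of the place differ: in compound 1 the chloro is ortho to a pyrrolidin-1-yl group (5 heavy atoms), whereas in compound 3 it is ortho to a 3-methylpiperazin-1-yl group (7 heavy atoms); the rest of the place, ortho to a fused ring, meta to a fluoro group (1 heavy atom) and meta to a fused ring, is shared.

Within the data shown here, on the single precedent, the step from compound 3 to compound 4 in this assay is expected to be small, about a 1.8-fold higher number from compound 3 to compound 4 (0.25 log units; within the scatter), because the earlier swap gave only a 1.9-fold higher number from compound 1 to compound 2 (0.27 log units; within the scatter), a step within the scatter. Compound 4 is therefore estimated at 80 ug/mL, with a likely range from 30 ug/mL to 200 ug/mL.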

Compound 4, half-maximal inhibitory concentration: 220 ug/mL
For compound 4 the middle estimate is 2.8-fold (0.44 log units) below the measured one, outside the stated range (above it).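

In this assay, trifluoromethyl in place of chloro on the core bearing the 3-methylpiperazin-1-yl group gives a 4.9-fold higher number from compound 3 to compound 4 (0.69 log units; beyond the scatter), a step beyond the scatter, yet the gap to the same swap on the pyrrolidin-1-yl core can still be scatter: the same change on two cores in this assay, a 1.9-fold higher number (0.27 log units; within the scatter) from compound 1 to compound 2 and a 4.9-fold higher number (0.69 log units; beyond the scatter) from compound 3 to compound 4, 2.6-fold (0.42 log units) apart, within the scatter of two such steps. The amine change, read on the trifluoromethyl core, gives a 1.3-fold lower number from compound 2 to compound 4 (0.10 log units; within the scatter), and its gap to the same change on the chloro core can likewise still be scatter: the same change on two cores in this assay, a 3.3-fold lower number (0.52 log units; beyond the scatter) from compound 1 to compound 3 and a 1.3-fold lower number (0.10 log units; within the scatter) from compound 2 to compound 4, 2.6-fold (0.42 log units) apart, within the scatter of two such steps. Each change therefore carries from one core to the other without a difference that can be told from scatter, but a single pair of cores does not show that a step has the same size on both, nor that it would hold on any further core.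

The compounds shown leave open how other amines on this aromatic carbon, such as morpholine or unsubstituted piperazine, or other groups in place of chloro, such as methyl, methoxy or nitrile, would behave. They also leave open whether these steps would persist with an ethyl group in place of the cyclopropyl group.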